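The source may report more compounds than this note shows. Statements on the series, on what has been measured and on what is new or still open speak of the compounds shown alone.

In an ADME assay on the whole organism with Oryza sativa as the target, tested at 0.1 uM (on this read-out lower numbers stand for a stronger effect and higher numbers for a weaker effect at the one concentration tested), compound 1 `Cc1ccc(NC(=O)N[C@@H](C)c2ccccc2)cc1` gives 100%, compound 2 `CC(C)c1ccc(NC(=O)N[C@@H](C)c2ccccc2)cc1` gives 98% and compound 3 `C[C@H](NC(=O)Nc1ccc(C(C)(C)C)cc1)c1ccccc1` gives 100%. Compound 3 thus stands level with compound 1, the two together the highest of the three numbers, with no change at the digits printed from compound 1 to compound 3 (within the scatter) and a number 2 percentage points higher from compound 2 to compound 3 (within the scatter). Compound 4 `CCCCCc1ccc(NC(=O)N[C@@H](C)c2ccccc2)cc1` differs from compound 3 by pentyl in place of tert-butyl on an aromatic carbon. Among the compounds with values here, the steps that bear on this are the other exchanges of an alkyl group on an aromatic carbon: a number 2 percentage points lower from compound 1 to compound 2 (within the scatter) and no change at the digits printed from compound 1 to compound 3 (within the scatter). Both lie within the scatter, so no step beyond the scatter is expected in this assay, only a number 1 percentage points lower from compound 3 to compound 4 (within the scatter). Compound 4 is therefore estimated at 99%, expected to fall between 88% and 100%.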

Compound 4, a percentage reported as activity, at one concentration (the size of the read-out at that concentration, not a potency): 98%
For compound 4 the middle estimate is 1 percentage points above the measured one; measured number inside the range.
By their numbers in this assay, from the lowest: compounds 2, 4, 1 and 3 (each within the scatter of the next).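

In this assay, an unbranched pentyl group on this aromatic carbon, para to a large group, reads much like the shorter or branched groups: there is a number 2 percentage points lower from compound 3 to compound 4 (within the scatter) and no change at the digits printed from compound 2 to compound 4 (within the scatter) and also a number 2 percentage points lower from compound 1 to compound 4 (within the scatter). Among these four compounds, then, neither branching nor the length of the alkyl group moves the number beyond the scatter. No measured evidence explains this result. From the compounds shown here alone, whether an amine, a carboxylic acid or a longer chain on this same carbon would shift the number remains open.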